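The compounds below may be only part of what the source reports. "The series", "measured", "known", "first", "only" and "open" are said of these compounds alone.

Of the compounds shown here, three built on one shared core have so far been tested in an assay on isolated protein for inhibition of Amine oxidase [flavin-containing] B (Homo sapiens), read by fluorescence, with a stated time of 20 min; a lower number here means a stronger inhibitor, a higher number a weaker inhibitor. Compound 2, `C/C(CC(C)C)=N/Nc1nc(-c2cccc([N+](=O)[O-])c2)cs1`, gives 12 nM. Compound 1, `CCC/C(C)=N\Nc1nc(-c2cccc([N+](=O)[O-])c2)cs1`, gives 55 nM in this assay. Compound 3, `CCCCC/C(CC)=N\Nc1nc(-c2cccc([N+](=O)[O-])c2)cs1`, gives 355 nM in this assay, the highest of the three numbers and therefore the weakest inhibitor among them.

The change from compound 2 to compound 1 is hydrogen in place of methyl on a saturated chain carbon bound to two saturated chain carbons, and it produced a 4.6-fold higher number from compound 2 to compound 1 (0.66 log units; beyond the scatter).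

Compound 4, `CCCC/C(CC)=N\Nc1nc(-c2cccc([N+](=O)[O-])c2)cs1`, has not yet been measured. It differs from compound 3 by hydrogen in place of methyl on a saturated chain carbon, four bonds along the chain from a carbon with a double bond to nitrogen. Among the measured compounds shown here, this is the same kind of change as the one from compound 2 to compound 1, but the place is not the same: in the earlier pair the carbon that loses its methyl is bound to two saturated chain carbons, whereas in compound 3 that carbon sits four bonds along the chain from a carbon with a double bond to nitrogen. How the core of compound 3 differs from the core of compound 2 is not broken down here, so the earlier step is only a loose guide.

In this assay a modestly lower number is expected from compound 3 to compound 4, a 1.8-fold lower number from compound 3 to compound 4 (0.25 log units; within the scatter), a step in the opposite direction to the earlier one, because compound 3 gives 355 nM while the shorter-chained compound 1 gives 55 nM. Compound 4 is therefore estimated at 200 nM, expected to fall between 70 nM and 600 nM.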

Compound 4, half-maximal inhibitory concentration: 182 nM
Beside the measured number, compound 4's estimate is 1.1-fold (0.04 log units) above it, and the stated range covers the measured number.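

In this assay, hydrogen in place of methyl on a saturated chain carbon, four bonds along the chain from a carbon with a double bond to nitrogen, gives a 2.0-fold lower number from compound 3 to compound 4 (0.29 log units; within the scatter), so this step alone does not separate the two compounds. Set beside the earlier step, the same kind of change does not carry over with the same size from one core to the other in this series: the same change on two cores in this assay, a 4.6-fold higher number (0.66 log units; beyond the scatter) from compound 2 to compound 1 and a 2.0-fold lower number (0.29 log units; within the scatter) from compound 3 to compound 4, 8.9-fold (0.95 log units) apart, beyond the scatter of two such steps

This comparison rests on a single pair of compounds for each core, and the methyl leaves a different place in each pair, so it does not show whether the core or the place lies behind the gap, nor what the change would do on any further core.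

The chains in the compounds shown are made of carbon and hydrogen alone, which leaves open what a chain carrying an amine or a carboxylic acid would give in this assay. Also open, going by these compounds, is whether the same change, made at one and the same place on two different cores, would give steps that agree.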